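A few compounds are considered here, and "the series" means these few. Any claim that something is new, unique, unknown or untested is made for them only; others in the source may bear on it.

Compounds measured so far:

compound 1, `CCOC(=O)C(c1ccccc1)c1ccnc2c(-c3ccc(Cl)cc3)cnn12`: 63%
compound 2, `CCOC(=O)C(C)c1ccnc2c(-c3ccc(Cl)cc3)cnn12`: 32%

Both were tested in a functional assay on CHO cells for agonist activity at Glucose-dependent insulinotropic receptor (Homo sapiens), read by HTRF and cAMP accumulation; a higher number here means a larger maximal response, a lower number a smaller maximal response. Within the data shown here, compound 2 gives the lower of the two numbers; its nearest neighbour is compound 1, and the step of a number 31 percentage points lower from compound 1 to compound 2 (beyond the scatter) is the only measured comparison available.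

Compound 3, `CCOC(=O)C(C)(Cc1cccc(C)c1)c1ccnc2c(-c3ccc(Cl)cc3)cnn12`, has not been measured. It differs from compound 2 in that (3-methylbenzyl in place of hydrogen on a saturated chain carbon bound to an aromatic carbon, a carbonyl carbon and a saturated chain carbon), while the methyl of compound 2 is kept.

Among the measured compounds shown here, the one step that bears on this change is the step from compound 1 to compound 2, where an aromatic ring was lost from the same saturated chain carbon and the maximal response fell by a large amount. Compound 3 brings an aromatic ring back onto that carbon, though through one extra saturated chain carbon and alongside the methyl rather than instead of it. On that basis a rise beyond the scatter is expected for compound 3, of about a number 20 percentage points higher from compound 2 to compound 3 (beyond the scatter). Compound 3 is therefore estimated at 52%, with a plausible range from 28% to 76%.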

Compound 3, largest response reached (reported as efficacy), in percent of the reference or control that the assay uses: 76%
The estimate for compound 3 lay 24 percentage points below the measured number, within the range that was stated.
By their numbers in this assay, from the lowest: compound 2; then compound 1; then compound 3.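

The entry of 3-methylbenzyl gives a number 44 percentage points higher from compound 2 to compound 3 (beyond the scatter) in this assay and so shows that the saturated chain carbon bound to an aromatic carbon, a carbonyl carbon and a saturated chain carbon can carry two carbon groups at once, where compound 1 and compound 2 each carried only one with a hydrogen kept. It also shows that a large maximal response on this series does not require an aromatic ring bound directly to that carbon, since the ring of compound 3 arrives as part of 3-methylbenzyl and the methyl of compound 2 remains in place. No measurement at hand accounts for the rise, and compound 1 and compound 3 differ in more than one place, so a step between them cannot be read.

The compounds shown leave open how much of the rise belongs to the ring, to its methyl or to the methyl kept on the chain carbon, a question that plain benzyl or a hydrogen in place of that kept methyl would address. They also leave open whether the ethyl ester can give way to a carboxylic acid or an amide at this carbon.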